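Swapping the aryl end of a chalcone for a furan ring

This account rests on a few compounds, and the source may have more. Where it says the series, first, only, none or still open, it means among the compounds named here.

Measured compounds:
- Compound 1, `O=C(CO[N+](=O)[O-])Nc1ccc(C(=O)/C=C/c2ccco2)cc1`, gives 40% in a functional assay on the whole organism (strain albino) for inhibition, with Rattus norvegicus as the target, read by paw edema, with stated times of 30 min and 4 h, at a dose of 100 mg/kg by the oral route; a lower number here means less inhibition, a higher number more inhibition at the dose given (going by the name of the read-out).
- Compound 2, `CC(=O)c1ccc(OCC(=O)Nc2ccc(C(=O)/C=C/c3ccc(Cl)cc3)cc2)cc1`, gives 58% in this assay.
- Compound 3, `COc1ccc(/C=C/C(=O)c2ccc(NC(=O)COc3ccc(C(C)=O)cc3)cc2)cc1`, gives 33% in this assay.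

Compound 3 sits beyond the scatter below compound 2 and within the scatter of compound 1. Among the compounds with values here, the only measured step that changes one place is a number 25 percentage points lower from compound 2 to compound 3 (beyond the scatter), which shows that the aryl end of the shared chain matters. Compound 4, `CC(=O)c1ccc(OCC(=O)Nc2ccc(C(=O)/C=C/c3ccco3)cc2)cc1`, differs from compound 3 in that same region: furan-2-yl in place of 4-methoxyphenyl on a double-bonded chain carbon bound to a double-bonded chain carbon. Within the data shown here, no measured step covers exactly this exchange. Compound 1 also carries furan-2-yl at that end, though with a different amide, and its value and that of compound 3 lie within the scatter of each other. On that basis the step of a number 11 percentage points higher from compound 3 to compound 4 (beyond the scatter) is expected to be small or upward at most modestly. Compound 4 is therefore estimated at 44%, with a likely range from 30% to 60%.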

Compound 4, a percentage reported as inhibition, in the whole organism at one dose (the size of the read-out at that dose, not a potency): 39%
Estimate against measurement, compound 4: 5 percentage points above; the range from low to high includes it.
By their numbers in this assay, from the lowest: compounds 3, 4 and 1 (each within the scatter of the next); then compound 2.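

Putting furan-2-yl in place of 4-methoxyphenyl gives a number 6 percentage points higher from compound 3 to compound 4 (within the scatter) in this assay and so does not separate these two ends of the chain. Putting furan-2-yl in place of 4-chlorophenyl gives a number 19 percentage points lower from compound 2 to compound 4 (beyond the scatter) with the rest of the molecule unchanged, so among these three ends only 4-chlorophenyl stands apart. With furan-2-yl held in place, 4-acetylphenyl in place of nitro on an oxygen on a saturated carbon gives a number 1 percentage points lower from compound 1 to compound 4 (within the scatter) and does not separate those two compounds either.

No measurement shown offers a reason for these steps. On these data alone, whether an amine or a carboxylic acid in place of the chloro group would keep the higher reading remains open. So does how these compounds would compare at other doses.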